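Adding a hydroxy to the lowest-numbered compound

The source may hold more compounds than are shown below. What is called first, only, known or untested is meant among the compounds shown, and "the series" means these compounds.

Measured in an ADME assay on L6 cells (Rattus norvegicus) for inhibition, read by fluorescence, with a stated time of 72 h; a lower number here means a stronger inhibitor, a higher number a weaker inhibitor:
- compound 1 `O=c1oc2ccccc2cc1Oc1ccc(Cl)cc1O`: 108000 nM
- compound 2 `O=c1oc2cc(O)ccc2cc1Oc1ccc(Cl)cc1O`: 144000 nM
- compound 3 `Cc1c(Oc2ccc(Cl)cc2O)c(=O)oc2ccccc12`: 51500 nM

Of these three, compound 3 has the lowest number, at 51500 nM. Its values show it ahead of both compound 1 and compound 2, though all three numbers remain high in this assay. The next compound, compound 4 `Cc1c(Oc2ccc(Cl)cc2O)c(=O)oc2cc(O)ccc12`, differs from compound 3 by one change: hydroxy in place of hydrogen on an aromatic carbon.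

The most direct evidence is the same replacement made without the methyl, which gave a 1.3-fold higher number from compound 1 to compound 2 (0.12 log units; within the scatter). The methyl replacement itself gave a 2.1-fold lower number from compound 1 to compound 3 (0.32 log units; beyond the scatter), a modest step that sets the starting point for compound 4 but says little about the hydroxy. Among the measured compounds shown here, no measured compound yet carries both groups, so whether the two steps simply add remains untested. Taking the hydroxy step as the guide, the expected change is a 1.3-fold higher number from compound 3 to compound 4 (0.12 log units; within the scatter), and no shift beyond the scatter is expected. For compound 4 the estimated value is 68000 nM, with an expected range from 36000 nM to 130000 nM.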

Compound 4, half-maximal inhibitory concentration: 96300 nM
The estimate for compound 4 lay 1.4-fold (0.15 log units) below the measured number; measured number inside the range.
By their numbers in this assay, from the lowest: compounds 3, 4, 1 and 2 (each within the scatter of the next, the first and the last beyond it).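

On the core that carries the methyl, hydroxy in place of hydrogen on an aromatic carbon, meta to a fused ring and para to a fused ring, gave a 1.9-fold higher number from compound 3 to compound 4 (0.27 log units; within the scatter) in this assay, so this change stays within the scatter with the methyl present as well as without it, and the two readings agree: the same change on two cores in this assay, a 1.3-fold higher number (0.12 log units; within the scatter) from compound 1 to compound 2 and a 1.9-fold higher number (0.27 log units; within the scatter) from compound 3 to compound 4, 1.4-fold (0.15 log units) apart, within the scatter of two such steps

The methyl replacement can now be read on the core that carries the hydroxy, where it gave a 1.5-fold lower number from compound 2 to compound 4 (0.17 log units; within the scatter), a step that does not pass the scatter as the step without the hydroxy did, although the two steps do not differ beyond the scatter of two such steps: the same change on two cores in this assay, a 2.1-fold lower number (0.32 log units; beyond the scatter) from compound 1 to compound 3 and a 1.5-fold lower number (0.17 log units; within the scatter) from compound 2 to compound 4, 1.4-fold (0.15 log units) apart, within the scatter of two such steps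

Compound 4 thus holds both groups, and these steps give no sign that either replacement changes the effect of the other beyond the scatter.

The compounds shown hold only hydrogen or hydroxy at this position, so what an amine or a methoxy group would do there remains open. As far as these compounds go, it also remains open whether the hydroxy step would stay this small with an ethyl group or a longer chain in place of the methyl.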